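A few compounds are considered here, and "the series" means these few. Any claim that something is new, unique, unknown or untested is made for them only; others in the source may bear on it.

In a functional assay on SMMC-7721 cells (Homo sapiens) for cytotoxicity, read by MTT assay, with a stated time of 48 h (a higher number here means a weaker inhibitor, a lower number a stronger inhibitor), three related compounds have been examined so far. For compound 1 `Cc1cc(Cl)cc2c(=O)cc(-c3ccc(Cl)cc3)oc12` the result is "not determined" (no result reported), so it offers no comparison. Compound 2 `CCN(CC)Cc1cc(Cl)cc2c(=O)cc(-c3ccc([N+](=O)[O-])cc3)oc12` gives 2990 nM, and compound 3 `CCN(CC)Cc1cc(Cl)cc2c(=O)cc(-c3ccccc3Cl)oc12` gives 810 nM. Compound 3 therefore holds the lower of the two available numbers, with compound 2 as its nearest neighbour.

The next compound, compound 4 `CN(C)Cc1cc(Cl)cc2c(=O)cc(-c3ccccc3Cl)oc12`, differs from compound 3 in one place: dimethylamino in place of diethylamino on a saturated chain carbon bound to an aromatic carbon. Dimethylamino stands in place of diethylamino on a saturated chain carbon bound to an aromatic carbon.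

Among the measured compounds shown here, only one measured step is available, a 3.7-fold lower number from compound 2 to compound 3 (0.57 log units; beyond the scatter). This modest step lies beyond the scatter, but it comes from 2-chlorophenyl replacing 4-nitrophenyl on an aromatic carbon, a change elsewhere in the molecule. It therefore bears only indirectly on the new change, showing how far one substitution has moved the numbers in this small set. For the measured compounds named here, no measured pair varies the amino group, so the data give no direction for this exchange. No step beyond the scatter is therefore expected in this assay, although the uncertainty is wide. The estimated step is a 1.2-fold higher number from compound 3 to compound 4 (0.07 log units; within the scatter). For compound 4 the estimated value is 950 nM, with an expected range from 350 nM to 2600 nM.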

Compound 4, half-maximal inhibitory concentration: 1140 nM
Compound 4: the middle estimate sits 1.2-fold (0.08 log units) below what was measured, within the range that was stated.
By their numbers in this assay, from the lowest: compounds 3 and 4 (each within the scatter of the next); then compound 2.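

In this assay, among the compounds shown here, this is the first measured change to the amino end of the molecule, as the earlier step concerned only 2-chlorophenyl in place of 4-nitrophenyl. With dimethylamino in place of diethylamino on a saturated chain carbon bound to an aromatic carbon, the group goes from 5 heavy atoms to 3, yet the result is a 1.4-fold higher number from compound 3 to compound 4 (0.15 log units; within the scatter) and the two compounds cannot be told apart in this assay. For the compounds shown here, this exchange therefore shows that, with the 2-chlorophenyl group in place, the two amino groups are interchangeable here, while the only earlier step, a 3.7-fold lower number from compound 2 to compound 3 (0.57 log units; beyond the scatter), came from the other end of the molecule and no reason for this outcome is available from any supporting data.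

On these data alone, whether a ring amine such as piperidine or morpholine, or a longer chain such as dipropylamino, would stay within the scatter of these two compounds remains open. As far as these compounds go, it is also open whether any amine is needed on this chain carbon, since a hydroxyl group or a primary amine there could give a quite different number.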